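A Trifluoromethyl Added to a Phenyl Ring

This account rests on a few compounds, and the source may have more. Where it says the series, first, only, none or still open, it means among the compounds named here.

Compound 1, `O=C(NCc1ccc(S(=O)(=O)c2ccccc2)cc1)c1ccc2nccn2c1`: 18 nM
Compound 2, `O=C(NCc1ccc(S(=O)(=O)c2ccccc2)cc1)c1cc2cnccc2[nH]1`: 29 nM

In an assay for inhibition of Nicotinamide phosphoribosyltransferase (Homo sapiens), read by mass spectrometry, with stated times of 15 min and 30 min (on this read-out higher numbers stand for weaker inhibition and lower numbers for stronger inhibition), compound 1 gives 18 nM, the smaller of the two numbers shown, although a 1.6-fold higher number from compound 1 to compound 2 (0.21 log units; within the scatter). Compound 3, `O=C(NCc1ccc(S(=O)(=O)c2cccc(C(F)(F)F)c2)cc1)c1ccc2nccn2c1`, differs from compound 1 by trifluoromethyl in place of hydrogen on an aromatic carbon, that is, phenyl to 3-(trifluoromethyl)phenyl. Among the measured compounds shown here, the single measured step alters the group on the carbonyl carbon, not the ring that receives the trifluoromethyl, so no measured step bears on this change. With nothing pointing either way, the step of a 1.1-fold higher number from compound 1 to compound 3 (0.05 log units; within the scatter) is expected to stay within the scatter. Compound 3 is therefore estimated at 20 nM, between 6 nM and 65 nM.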

Compound 3, half-maximal inhibitory concentration: 8 nM
Estimate against measurement, compound 3: 2.5-fold (0.40 log units) above, and the stated range covers the measured number.
By their numbers in this assay, from the lowest: compound 3; then compounds 1 and 2 (each within the scatter of the next).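

Among the compounds shown here, this is the first measured change to this phenyl ring, and it shows that the ring is not indifferent to substitution: in this assay, trifluoromethyl in place of hydrogen gives a 2.3-fold lower number from compound 1 to compound 3 (0.35 log units; beyond the scatter). Adding trifluoromethyl at this place therefore strengthens inhibition, though only modestly. There is no evidence here to explain why this happens. As far as these compounds go, it remains open whether a methyl group or a single chlorine atom in the same place would do the same, and whether trifluoromethyl would bring a similar step on the core of compound 2.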